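A few compounds are considered here, and "the series" means these few. Any claim that something is new, unique, unknown or untested is made for them only; others in the source may bear on it.

Measured compounds and their values in an assay on isolated protein for inhibition of tyrosine-protein kinase receptor UFO (Homo sapiens), read by TR-FRET, with a stated time of 60 min; a lower number here means a stronger inhibitor, a higher number a weaker inhibitor:

compound 1, `Cc1cnc(Nc2ccc(N3CCN(C)CC3)c(F)c2)nc1-c1ccc(F)cc1`, gives 6100 nM
compound 2, `Cc1cnc(Nc2ccc(CN3CCN(C)CC3)cc2)nc1-c1ccc(F)cc1S(=O)(=O)N1CCCC1`, gives 2930 nM

Of the two numbers shown, compound 2 has the lower one, which means the stronger inhibition in this assay. Its nearest neighbour is compound 1, whose number is higher by a gap that lies beyond the usual scatter of repeated measurements, so the two compounds are genuinely told apart by this assay. For the measured compounds named here, nothing is known from this pair alone about the single change that leads on to compound 3.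

Compound 3, `CN1CCN(Cc2ccc(Nc3ncc(F)c(-c4ccc(F)cc4S(=O)(=O)N4CCCC4)n3)cc2)CC1`, is not yet measured. It differs from compound 2 in one place: fluoro in place of methyl on an aromatic carbon. The group that leaves and the group that enters are each a single heavy atom, with no ring, no hydrogen-bond donor and no hydrogen-bond acceptor, and the rest of the molecule is kept. Going by the values given here, with no measured pair showing this kind of exchange, the size of the step is open; the expectation here is no change beyond the scatter, in either direction. On that basis compound 3 is expected to give 2600 nM in this assay, with a likely range from 1000 nM to 7000 nM, corresponding to a step of a 1.1-fold lower number from compound 2 to compound 3 (0.05 log units; within the scatter) that is expected to stay within the scatter.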

Compound 3, half-maximal inhibitory concentration: 1150 nM
Beside the measured number, compound 3's estimate is 2.3-fold (0.35 log units) above it, and the stated range covers the measured number.
By their numbers in this assay, from the lowest: compound 3; then compound 2; then compound 1.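

In this assay, replacing methyl with fluoro on the aromatic carbon of the six-membered aromatic ring with 2 nitrogen gives a 2.5-fold lower number from compound 2 to compound 3 (0.41 log units; beyond the scatter). For the compounds shown here, this is the first measured pair in which only one place differs, so the modest change can be tied to this carbon and this exchange, and it shows that swapping one heavy atom for another here can shift the number beyond the scatter. The pair records the size and direction of the step but gives no measured property that accounts for it, and no supporting data bear on why fluoro gives the lower number.

With only methyl and fluoro shown at this carbon, it remains open whether chloro, a nitrile, an amine or a longer chain such as ethyl would lower the number further, leave it unchanged or raise it. On these data alone, it is also open whether fluoro in place of methyl would give a step of similar size if the groups elsewhere on the shared core were different.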